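The source may hold more compounds than are shown below. What is called first, only, known or untested is meant among the compounds shown, and "the series" means these compounds.

Measured compounds:
compound 1 `CC(C)(C)c1ccc(CN2CC[C@H](Oc3cccc4ccc(N)nc34)C2)cc1`; in a functional assay on IMR-32 cells with melanin-concentrating hormone receptor 1 (Homo sapiens) as the target, read by fluorescence (a lower number here means a stronger inhibitor, a higher number a weaker inhibitor), compound 1 gives 30 nM
compound 2 `CC(C)Cc1ccc(N2CCC(Oc3cccc4ccc(N)nc34)C2)cc1`; in this assay compound 2 gives 53.3 nM

Among the compounds with values here, compound 2 has the higher of the two numbers so far, but its only neighbour, compound 1, sits within the scatter of it, so the two are not distinguishable on these data. Within the data shown here, no pair differing in a single place has been measured, so no step size is available yet.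

Compound 3 `CC(C)Cc1ccc(N2CCC(Oc3cccc4ccc(NCC5CC5)nc34)C2)cc1` follows from compound 2 by one change, cyclopropylmethyl in place of hydrogen on a nitrogen on an aromatic ring, which reads as amino to (cyclopropylmethyl)amino one bond further out. Nothing in the measured set tests a substituent on this nitrogen, so the expectation rests on the change itself. A modest rise in the number, in this assay, somewhat beyond the scatter, is expected; a result inside the scatter would not be surprising. The estimated step is a 2.4-fold higher number from compound 2 to compound 3 (0.39 log units; beyond the scatter). Compound 3 is estimated at 130 nM, in the range 35 nM to 500 nM.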

Compound 3, half-maximal inhibitory concentration: > 10000 nM
Compound 3: no number, only a limit; the forecaster's own chance of this, stated with the estimate: 5%; middle value at least 76-fold (1.88 log units) away from the limit.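

Within the data shown here, the first substituent tested on this nitrogen shows that the position is far from indifferent in this assay: cyclopropylmethyl in place of hydrogen gives an at least 180-fold higher number from compound 2 to compound 3 (2.27 log units; beyond the scatter), a large step where the earlier compounds offered no single-place comparison at all. The value of compound 3 is a limit and not a number, so the step fixes only a minimum size and the real distance remains unknown: the limit of > 10000 nM in this assay, at which 1 of the 3 values shown sits. Within the compounds shown, the unsubstituted amino group therefore goes with a measurable inhibitor and the (cyclopropylmethyl)amino group with none up to that limit, although this rests on a single pair and no cause can be read from it.

Still open, as far as these compounds go, is whether the loss belongs to cyclopropylmethyl specifically or to any substituent on this nitrogen, a question that a methyl group or an acetyl group at the same place would address. Also open, from the compounds shown here alone, is whether the same change would have a comparable effect in the setting of compound 1, which differs from compound 2 in more than one place.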